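Working notes: from compound 2 to compound 3

A few compounds are considered here, and "the series" means these few. Any claim that something is new, unique, unknown or untested is made for them only; others in the source may bear on it.

Compound 1 `Cc1ccc(CN2CCC(c3noc(CN(C)c4ncc(/C=C/C(=O)NO)cn4)n3)CC2)cc1`: 293 nM
Compound 2 `Cc1cccc(CN2CCC(c3noc(CN(C)c4ncc(C(=O)NO)cn4)n3)CC2)c1`: 47.3 nM

Both values come from a functional assay on Raji cells (Homo sapiens) for antiproliferative activity, read by MTT assay, with a stated time of 72 h; on this read-out higher numbers stand for weaker inhibition and lower numbers for stronger inhibition. Compound 2 holds the lower of the two numbers and so shows the stronger inhibition, while compound 1 stands higher by a gap beyond the usual scatter.

The unmeasured compound 3 `CN(Cc1nc(C2CCN(Cc3ccccc3Cl)CC2)no1)c1ncc(C(=O)NO)cn1` departs from compound 2 in one place: 2-chlorophenyl in place of 3-methylphenyl on a saturated chain carbon bound to an amine nitrogen in a ring. In words, 2-chlorophenyl stands in place of 3-methylphenyl on a saturated chain carbon bound to an amine nitrogen in a ring.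

Going by the values given here, no measured pair shows what a change at this place does in this assay, so the data give no ground for expecting a large step in either direction. The expectation therefore stays close to compound 2 at 47.3 nM, with no step beyond the scatter. The estimated change is a 1.2-fold higher number from compound 2 to compound 3 (0.07 log units; within the scatter), which is expected to stay within the scatter. For compound 3 the estimated value is 55 nM, with an expected range of 20 nM to 150 nM.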

Compound 3, half-maximal inhibitory concentration: 48.3 nM
Compound 3: the middle estimate sits 1.1-fold (0.06 log units) above what was measured, within the range that was stated.
By their numbers in this assay, from the lowest: compounds 2 and 3 (each within the scatter of the next); then compound 1.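

Going by these compounds alone, this is the first pair in this assay that differs in one place, and it reads a 1.0-fold higher number from compound 2 to compound 3 (0.01 log units; within the scatter). The values of compound 2 and compound 3 cannot be told apart, so at this place on a saturated chain carbon bound to an amine nitrogen in a ring, 2-chlorophenyl and 3-methylphenyl read alike in this cell assay, although the swap alters both the kind of substituent and where it stands on the phenyl ring. No measurement of a property of either group or of target engagement bears on this result, so the series offers no explanation for it.

Within the data shown here, the single step cannot separate the kind of substituent from its location, and 3-chlorophenyl and 2-methylphenyl groups would be needed to pull those two apart. Also open, on these data alone, is whether the same flat reading holds for more distinct groups at this place, such as a phenyl ring carrying a carboxylic acid or an aminomethyl group, or a longer chain such as 2-phenylethyl in place of the benzyl group, and whether it carries over to the core of compound 1.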